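Replacing methoxy with trifluoromethyl on the anilide

The compounds below may be only part of what the source reports. "The series", "measured", "known", "first", "only" and "open" are said of these compounds alone.

compound 1 (`Cc1ccc(NC(=O)COc2ccc3cc(/C=C4/SC(=O)NC4=O)ccc3c2)cc1`) gives 7000 nM
compound 2 (`COc1cccc(NC(=O)COc2ccc3cc(/C=C4/SC(=O)NC4=O)ccc3c2)c1`) gives 9300 nM

Within the data shown here, in a functional assay on Ramos cells (Homo sapiens) for cytotoxicity, with a stated time of 20 h (on this read-out lower numbers stand for higher toxicity in this test and higher numbers for lower toxicity in this test), compound 2 gives 9300 nM and lies within the scatter of compound 1, the only other measured compound. Compound 3 (`O=C(COc1ccc2cc(/C=C3/SC(=O)NC3=O)ccc2c1)Nc1cccc(C(F)(F)F)c1`) differs from compound 2 by trifluoromethyl in place of methoxy on an aromatic carbon (trifluoromethyl in place of methoxy on an aromatic carbon, meta to a large group). Among the measured compounds shown here, the one measured step bearing on this is a 1.3-fold higher number from compound 1 to compound 2 (0.12 log units; within the scatter) and stays within the scatter. One step is thin evidence, but no change beyond the scatter is expected in this assay here. The expected step is a 1.3-fold lower number from compound 2 to compound 3 (0.12 log units; within the scatter) by this estimate. Compound 3 is estimated at 7000 nM with an expected range from 3000 nM to 16000 nM in this test.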

Compound 3, half-maximal cytotoxic concentration: 6200 nM
For compound 3 the middle estimate is 1.1-fold (0.05 log units) above the measured one, within the range that was stated.
By their numbers in this assay, from the lowest: compounds 3, 1 and 2 (each within the scatter of the next).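

In this assay, trifluoromethyl in place of methoxy on the aromatic carbon gives a 1.5-fold lower number from compound 2 to compound 3 (0.18 log units; within the scatter) and 3-(trifluoromethyl)phenyl in place of 4-methylphenyl on the amide-type nitrogen gives a 1.1-fold lower number from compound 1 to compound 3 (0.05 log units; within the scatter) and both steps stay within the scatter. This position therefore accepts trifluoromethyl as well as methoxy, without a change that this test can resolve, and the three anilides cannot be told apart. No measured evidence on these compounds bears on this result.

As far as these compounds go, whether an amine or a carboxylic acid at this position would move the number beyond the scatter stays open.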